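The source may hold more compounds than are shown below. What is called first, only, known or untested is meant among the compounds shown, and "the series" means these compounds.

Measured so far:
compound 1 `N=C(Nc1cccc(C(F)(F)F)c1)c1cc2cn[nH]c2cn1` gives 36500 nM in a functional assay on HT-1080 cells (Homo sapiens) for cytotoxicity, read by MTT assay, with a stated time of 72 h; a higher number here means a weaker inhibitor, a lower number a stronger inhibitor
compound 2 `Cn1ncc2cc(C(=N)Nc3cccc(C(F)(F)F)c3)ncc21` gives 33800 nM in this assay

Among the measured compounds shown here, compound 2 holds the lower of the two numbers in this assay, yet its only neighbour, compound 1, stands within the scatter of it, so neither can be called the stronger. For the measured compounds named here, the single measured step, a 1.1-fold lower number from compound 1 to compound 2 (0.03 log units; within the scatter), is the one that bears on the next change, since both alter the same aromatic nitrogen. Compound 3 `COc1ccc(Cn2ncc3cc(C(=N)Nc4cccc(C(F)(F)F)c4)ncc32)cc1` carries 4-methoxyphenyl in place of hydrogen on a saturated chain carbon bound to an aromatic nitrogen, a far larger addition than the methyl for hydrogen exchange already seen, so that step is a weak guide. With no other data, a modest shift in this assay is expected, of about a 1.7-fold lower number from compound 2 to compound 3 (0.23 log units; within the scatter), with a real chance the number stays within the scatter. Compound 3 is therefore estimated at 20000 nM, with a range from 5000 nM to 60000 nM.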

Compound 3, half-maximal inhibitory concentration: 24900 nM
Estimate against measurement, compound 3: 1.2-fold (0.10 log units) below; the range from low to high includes it.
By their numbers in this assay, from the lowest: compounds 3, 2 and 1 (each within the scatter of the next).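

Compound 1 and compound 2 had shown only that a methyl group on this aromatic nitrogen leaves the number within the scatter; in this assay the much larger 4-methoxybenzyl group, reached by adding 4-methoxyphenyl with its 8 heavy atoms, also stays within it, with a 1.4-fold lower number from compound 2 to compound 3 (0.13 log units; within the scatter) and a 1.5-fold lower number from compound 1 to compound 3 (0.17 log units; within the scatter). This position therefore carries hydrogen, methyl or 4-methoxybenzyl with all three compounds inside one band of values, so added size alone does not separate them here. Nothing available explains this result.

On these data alone, whether a carboxylic acid or an amine at the end of a longer chain on this nitrogen would carry the number beyond the scatter remains open. So does whether a nitrile in place of trifluoromethyl would do so.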